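Replacing a Small Ring with a Bulkier One

The source may hold more compounds than are shown below. What is called first, only, known or untested is meant among the compounds shown, and "the series" means these compounds.

Three compounds share one core and differ only in the group on the side. Compound 1 `O=C(CC1CCCCC1)N1CCN(c2nc(=O)c3cc(C(F)(F)F)cc([N+](=O)[O-])c3s2)CC1` carries a cyclohexylmethyl on a carbonyl carbon, compound 2 `CC1COC2(CCN(c3nc(=O)c4cc(C(F)(F)F)cc([N+](=O)[O-])c4s3)CC2)O1` a different side group, and compound 3 `O=C(C1CC1)N1CCN(c2nc(=O)c3cc(C(F)(F)F)cc([N+](=O)[O-])c3s2)CC1` a cyclopropyl on a carbonyl carbon. In an ADME assay on Vero cells (Chlorocebus sabaeus) for cytotoxicity, read by MTT assay, with a stated time of 72 h (on this read-out higher numbers stand for lower toxicity in this test and lower numbers for higher toxicity in this test), compound 1 gives > 125000 nM, which is a limit of the assay rather than a number. Compound 2 likewise gives only a limit, > 125000 nM. Compound 3 also reaches only a limit, > 125000 nM, so it stands at the ceiling of what was measured. For the measured compounds named here, because every value sits at the limit of > 125000 nM in this assay, at which 3 of the 3 values shown sit, the one measured step, a step that the two limits leave unreadable from compound 1 to compound 3, cannot be read. Compound 4 `CC(C)(C)C1CCC(C(=O)N2CCN(c3nc(=O)c4cc(C(F)(F)F)cc([N+](=O)[O-])c4s3)CC2)CC1` is not yet measured; it differs from compound 3 by 4-(tert-butyl)cyclohexyl in place of cyclopropyl on a carbonyl carbon. Going by the values given here, the only measured step on a carbonyl carbon is unreadable, so no direction can be drawn from it. Compound 4 is therefore expected to reach the same limit, with an expected step of a number no higher from compound 3 to compound 4 (the limit leaves the size open) and an estimated value of 125000 nM, between 60000 nM and 250000 nM.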

Compound 4, half-maximal cytotoxic concentration: > 125000 nM
Compound 4 gave a limit, no number (the forecaster's own chance of this, stated with the estimate: 80%); the middle value sits exactly at the limit.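

Compound 4 gives only a limit, as do compound 1 and compound 3, so neither step to compound 4 can be read: the limit of > 125000 nM in this assay, at which 4 of the 4 values shown sit.

The compounds shown leave open whether any of these side groups on the carbonyl carbon changes the read-out in this assay, since none of them yields an actual number.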